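Trading chloro for trifluoromethyl in compound 1

This account rests on a few compounds, and the source may have more. Where it says the series, first, only, none or still open, it means among the compounds named here.

Compound 1 `O=C(NCc1ccccc1Cl)N1C(=O)c2ccccc2S1(=O)=O` gives 0.42 h
Compound 2 `O=C(NCc1cccs1)N1C(=O)c2ccccc2S1(=O)=O` gives 0.365 h

In a physicochemical assay for pharmacokinetics (a higher number here means that the compound lasts longer, a lower number that the compound disappears faster), compound 1 stands at 0.42 h and compound 2 at 0.365 h so the two cannot be told apart. Neither compound stands clear of the other, and two compounds give only a narrow view.

The unmeasured compound 3 `O=C(NCc1ccccc1C(F)(F)F)N1C(=O)c2ccccc2S1(=O)=O` keeps the core of compound 1 and changes one group: trifluoromethyl in place of chloro on an aromatic carbon which means trifluoromethyl in place of chloro on an aromatic carbon, ortho to a large group.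

Within the data shown here, only one measured step offers guidance, and only loosely. That step, a 1.2-fold lower number from compound 1 to compound 2 (0.06 log units; within the scatter) exchanged the whole 2-chlorophenyl group for thiophen-2-yl, so it does not test the present change directly. Among the measured compounds shown here, nothing measured so far shows how chloro and trifluoromethyl compare. No shift beyond the scatter is therefore expected in this assay in either direction.

The estimated change is a 1.1-fold lower number from compound 1 to compound 3 (0.02 log units; within the scatter) and it remains small. For compound 3 the estimate is 0.4 h with 0.22 h to 0.75 h as its expected range.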

Compound 3, half-life: 0.187 h
The estimate for compound 3 lay 2.1-fold (0.33 log units) above the measured number; the measured number lies below the stated range.
By their numbers in this assay, from the lowest: compounds 3, 2 and 1 (each within the scatter of the next, the first and the last beyond it).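

In this assay, trifluoromethyl in place of chloro on an aromatic carbon, ortho to a large group, gives a 2.2-fold lower number from compound 1 to compound 3 (0.35 log units; beyond the scatter). Among these compounds, the earlier step, a 1.2-fold lower number from compound 1 to compound 2 (0.06 log units; within the scatter), exchanged the whole 2-chlorophenyl group for thiophen-2-yl and stayed within the scatter, so the earlier compounds gave no sign that this part of the molecule could shift the half-life at all, whereas the new step shows that changing one group on that ring can do so, if only modestly. Chloro brings one heavy atom and trifluoromethyl brings four, but that count only describes the change, and no measurement here explains why the number fell.

From the compounds shown here alone, this is a single pair, so it remains open whether a methyl or a methoxy group on the same aromatic carbon would also lower the number, or whether the loss belongs to trifluoromethyl alone. Also open, going by these compounds, is whether any group there could lift the half-life beyond that of compound 1, at 0.42 h, rather than only lower it.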